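The source may report more compounds than this note shows. Statements on the series, on what has been measured and on what is new or still open speak of the compounds shown alone.

Of the compounds shown here, three sharing one core have been tested in an ADME assay on microsomes from liver (Homo sapiens) for metabolic stability; on this read-out lower numbers stand for slow clearance and higher numbers for fast clearance. Compound 1 (`Cc1ccc2[nH]c(C(=O)N[C@H]3CN(S(=O)(=O)c4ccccc4)C[C@@H]3C(=O)NC[C@H]3CCCN3)cc2c1`) gives < 3 mL.min-1.g-1, which is a limit of the assay and not a number. Compound 2 (`O=C(N[C@H]1CN(S(=O)(=O)c2ccccc2)C[C@@H]1C(=O)N[C@H]1CCCNC1)c1cn(C2CC2)cn1`) gives < 3 mL.min-1.g-1, which is also a limit. For the measured compounds named here, compound 3 (`O=C(N[C@H]1CN(S(=O)(=O)c2ccccc2)C[C@@H]1C(=O)N1C[C@H]2CCNC[C@H]21)c1cc(-c2ccccc2Cl)on1`) gives 7.3 mL.min-1.g-1, the only true number of the three.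

Compound 4 (`CN(C(=O)[C@H]1CN(S(=O)(=O)c2ccccc2)C[C@@H]1NC(=O)c1cc(-c2ccccc2Cl)on1)[C@H]1CCCNC1`) keeps the core of compound 3 and changes one place, on a carbonyl carbon: a group of 8 heavy atoms (6 carbon, 2 nitrogen; one six-membered non-aromatic ring with 1 hetero atom) in place of a group of 8 heavy atoms (6 carbon, 2 nitrogen; one four-membered non-aromatic ring with 1 hetero atom, one six-membered non-aromatic ring with 1 hetero atom), on a carbonyl carbon. Going by the values given here, compound 1 and compound 2 each differ from compound 3 in more than one place, so no measured pair shows what a single change of this kind does in this assay. The expectation is therefore no change beyond the usual scatter, anchored on compound 3 at 7.3 mL.min-1.g-1. The estimated 1.1-fold higher number from compound 3 to compound 4 (0.04 log units; within the scatter) is small for that reason. Compound 4 is expected at about 8 mL.min-1.g-1, with an estimated range from 3.5 mL.min-1.g-1 to 18 mL.min-1.g-1.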

Compound 4, intrinsic clearance in microsomes: 4.2 mL.min-1.g-1
The estimate for compound 4 lay 1.9-fold (0.28 log units) above the measured number; measured number inside the range.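

In this assay, for the compounds shown here, this is the first step that changes a single place on the shared core: a 1.7-fold lower number from compound 3 to compound 4 (0.24 log units; within the scatter). On this carbonyl carbon, a group with one six-membered non-aromatic ring takes the place of a group with a four-membered and a six-membered non-aromatic ring, with the same count of heavy atoms and one defined stereocentre fewer, and the step stays within the scatter, so losing the four-membered ring shows no clear effect on clearance here. Both compounds of this step give true numbers, and a limit of the read-out lies not far off: the limit of < 3 mL.min-1.g-1 in this assay, at which 2 of the 4 values shown sit.

From the compounds shown here alone, whether any group on this carbonyl carbon moves clearance beyond the scatter remains open, for example an open chain ending in an amine or a carboxylic acid. Going by these compounds, it is also open whether this same exchange would behave alike with a different group on the other amide of the core.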